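The source may hold more compounds than are shown below. What is called first, only, known or untested is meant among the compounds shown, and "the series" means these compounds.

The measured compounds and their values:

Compound 1, `CCc1ccc(Nc2nc3nonc3nc2O)cc1`, gives 10700 nM in an assay on mitochondria from L6 cells (Rattus norvegicus) for activation, with a stated time of 90 min; on this read-out lower numbers stand for an effect already at smaller amounts and higher numbers for an effect only at larger amounts of compound.
Compound 2, `CCc1ccc(Nc2nc3nonc3nc2O)c(F)c1`, gives 6700 nM in this assay.
Compound 3, `Oc1nc2nonc2nc1Nc1cccc(C(F)(F)F)c1`, gives 13300 nM in this assay.

Compounds 1 and 2 share a core and differ in one place: fluoro in place of hydrogen on an aromatic carbon. In this assay this change made a 1.6-fold lower number from compound 1 to compound 2 (0.20 log units; within the scatter). The two values therefore do not separate from each other, and nothing can be said about an order between compound 1 and compound 2.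

Compound 3 carries a trifluoromethyl group in place of the ethyl group of compound 1; the difference between the two cores is not broken down here. Its value stands near that of compound 1 and within the scatter of both measured compounds.

Compound 4, `Oc1nc2nonc2nc1Nc1cc(C(F)(F)F)ccc1F`, has not yet been measured. It differs from compound 3 in one place: fluoro in place of hydrogen on an aromatic carbon. Within the data shown here, this is the same kind of change as the one from compound 1 to compound 2, but not the same: in compound 2 the fluoro enters ortho to a large group and meta to an ethyl group, whereas in compound 4 it enters ortho to a large group and para to a trifluoromethyl group. Among the measured compounds shown here, with only one earlier instance of the change, and that one within the scatter, the expected step from compound 3 to compound 4 in this assay is small: an estimated 1.5-fold lower number from compound 3 to compound 4 (0.17 log units; within the scatter), resting on the step from compound 1 to compound 2, which was a 1.6-fold lower number from compound 1 to compound 2 (0.20 log units; within the scatter). Compound 4 is accordingly expected to give about 9000 nM, most likely between 4000 nM and 20000 nM.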

Compound 4, half-maximal effective concentration: 5100 nM
For compound 4 the middle estimate is 1.8-fold (0.25 log units) above the measured one, and the stated range covers the measured number.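

In this assay, fluoro in place of hydrogen on an aromatic carbon gave a 2.6-fold lower number from compound 3 to compound 4 (0.42 log units; beyond the scatter), a modest step that lies beyond the scatter, whereas the same change on the core of compound 1 stayed within it. Even so, the two steps cannot be told apart in size: the same change on two cores in this assay, a 1.6-fold lower number (0.20 log units; within the scatter) from compound 1 to compound 2 and a 2.6-fold lower number (0.42 log units; beyond the scatter) from compound 3 to compound 4, 1.6-fold (0.21 log units) apart, within the scatter of two such steps. This shows that the two pairs are compatible with one shared step size for this change, but it does not show that the change acts more strongly with a trifluoromethyl group than with an ethyl group, and two pairs set no rule for other cores in the series.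

The compounds shown leave open how the step would look with another group in the place of the fluoro, such as a chlorine atom, a methoxy group or a nitrile, and whether it would hold with an amine or a carboxylic acid in the place of the ethyl or trifluoromethyl group. They also leave open whether the same step would appear on any read-out other than this assay, since the comparison rests on that single assay.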